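Adding a Second Trifluoromethyl to Compound 1

A few compounds are considered here, and "the series" means these few. Any claim that something is new, unique, unknown or untested is made for them only; others in the source may bear on it.

Four compounds share a common core and are compared in a functional assay on A549 cells (Homo sapiens) for inhibition, read by MTT assay, with a stated time of 72 h; a lower number here means a stronger inhibitor, a higher number a weaker inhibitor. Compound 1 (`CNc1nc(C(F)(F)F)c(C(=O)N/N=C/c2cccc(C(F)(F)F)c2)s1`) carries a single trifluoromethyl on its outer aromatic ring. In this assay compound 1 gives > 100 ug/mL, which is a limit of the assay rather than a number. Compound 2 (`CN(C(=O)NC(=O)c1ccc(C(F)(F)F)cc1)c1nc(C(F)(F)F)c(C(=O)N/N=C/c2cccc(C(F)(F)F)c2)s1`) differs from compound 1 in more than one place, and the difference between the two cores is not broken down here. In this assay compound 2 gives 6.66 ug/mL. Compound 3 (`CN(C(=O)NC(=O)c1ccc(C(F)(F)F)cc1)c1nc(C(F)(F)F)c(C(=O)N/N=C/c2cc(C(F)(F)F)cc(C(F)(F)F)c2)s1`) is compound 2 with one change, (trifluoromethyl in place of hydrogen on an aromatic carbon), and in this assay compound 3 gives 5.9 ug/mL. The step this change made is a 1.1-fold lower number from compound 2 to compound 3 (0.05 log units; within the scatter), so the two values are indistinguishable within the usual scatter.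

Compound 4 (`CNc1nc(C(F)(F)F)c(C(=O)N/N=C/c2cc(C(F)(F)F)cc(C(F)(F)F)c2)s1`) is compound 1 with the same change, (trifluoromethyl in place of hydrogen on an aromatic carbon), at the same kind of place: on an aromatic carbon of a six-membered aromatic ring of carbon only, meta to a large group and meta to a trifluoromethyl group. On these data alone, because the same change moved nothing measurable in a 1.1-fold lower number from compound 2 to compound 3 (0.05 log units; within the scatter), the expectation for compound 4 is a step that the limit leaves unreadable from compound 1 to compound 4, with the reservation that compound 1 sits at the limit of > 100 ug/mL in this assay, at which 1 of the 3 values shown sits, so the true size of its starting point is unknown. The estimate for compound 4 in this assay is therefore 150 ug/mL, most likely reported again only as a limit.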

Compound 4, half-maximal inhibitory concentration: > 100 ug/mL
Compound 4: only a limit was reported (the forecaster's own chance of this, stated with the estimate: 80%); the middle value is on the limit's open side.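

In this assay compound 4 gives > 100 ug/mL, which is a limit of the assay and not a number. Among the compounds shown here, compound 1 also has only a limit, so no step from compound 1 to compound 4 can be read: the limit of > 100 ug/mL in this assay, at which 2 of the 4 values shown sit. The compounds shown leave open how strong compound 1 and compound 4 truly are, and whether the added trifluoromethyl changes anything on the core they share.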